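Lengthening the Amine-Bearing Chain in Three Close Analogues

The compounds below may be only part of what the source reports. "The series", "measured", "known", "first", "only" and "open" are said of these compounds alone.

Three compounds have been measured:
compound 1, `O=c1oc2cc(O)ccc2c(Cc2ccc(OCCCN3CCCCC3)cc2)c1-c1ccccc1`, 18 nM
compound 2, `O=c1oc2cc(O)ccc2c(-c2ccc(OCCCCN3CCCCC3)cc2)c1-c1ccccc1`, 134 nM
compound 3, `O=c1oc2cc(O)ccc2c(-c2ccc(OCCCCCN3CCCCC3)cc2)c1-c1ccccc1`, 335 nM

These values come from a functional assay on MCF7 cells (Homo sapiens) for antiproliferative activity; on this read-out higher numbers stand for weaker inhibition and lower numbers for stronger inhibition. Compound 1 gives the lowest number of the three, with compound 2 the nearest to it and compound 3 the furthest. Compound 1 and compound 2 are built from the same atoms joined differently; the difference between the two cores is not broken down here. Within the core of compound 2, the step of a 2.5-fold higher number from compound 2 to compound 3 (0.40 log units; beyond the scatter) is made by (piperidin-1-yl)methyl in place of piperidin-1-yl on a saturated chain carbon, four bonds along the chain from an oxygen on an aromatic ring.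

The unmeasured compound 4, `O=c1oc2cc(O)ccc2c(Cc2ccc(OCCCCN3CCCCC3)cc2)c1-c1ccccc1`, arises from compound 1 by (piperidin-1-yl)methyl in place of piperidin-1-yl on a saturated chain carbon, three bonds along the chain from an oxygen on an aromatic ring. This is the same kind of change as from compound 2 to compound 3, but around a different place: in compound 1 the saturated chain carbon sits three bonds along the chain from the oxygen on the aromatic ring, whereas in compound 2 it sits four bonds along. Because of a 2.5-fold higher number from compound 2 to compound 3 (0.40 log units; beyond the scatter), a similar modest rise is expected here, a 2.5-fold higher number from compound 1 to compound 4 (0.40 log units; beyond the scatter). Compound 4 is therefore estimated at 45 nM, within a range from 18 nM to 110 nM.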

Compound 4, half-maximal inhibitory concentration: 13 nM
Compound 4: middle estimate off by 3.5-fold (0.54 log units), on the high side; the whole stated range lies above it.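

On the core of compound 1, the same lengthening of the chain gives a 1.4-fold lower number from compound 1 to compound 4 (0.14 log units; within the scatter), so compound 1 and compound 4 cannot be told apart in this assay. The rise seen on the core of compound 2 therefore does not carry over to the core of compound 1, and the two steps differ by more than chance scatter would readily explain: the same change on two cores in this assay, a 2.5-fold higher number (0.40 log units; beyond the scatter) from compound 2 to compound 3 and a 1.4-fold lower number (0.14 log units; within the scatter) from compound 1 to compound 4, 3.5-fold (0.54 log units) apart, beyond the scatter of two such steps

This shows that the effect of this change depends on the core it is made on, at least for these two cores, but it rests on a single pair of steps and does not show why the cores differ or how the trend would continue. The compounds shown leave open whether a longer chain on the core of compound 1 would eventually raise the number as it does on the core of compound 2. They also leave open whether a morpholine in place of the piperidine at the chain end would follow the same behaviour on both cores.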